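Swapping an aryl ring for a pyridone on the shared core

The source may report more compounds than this note shows. Statements on the series, on what has been measured and on what is new or still open speak of the compounds shown alone.

Among the compounds with values here, compound 1 `COc1cc(F)ccc1-c1ccnc2[nH]c(C3CCN(CC(=O)N(C)C)CC3)cc12` is one of two compounds measured in an ADME assay on cells (Hepatocyte, Rattus norvegicus) for metabolic stability (a lower number here means slower removal, a higher number faster removal of the compound), where compound 1 gives 38 uL/min, the higher of the two numbers. Compound 2 `CC(C)Cn1cc(-c2ccnc3[nH]c(C4CCN(CC(=O)N(C)C)CC4)cc23)ccc1=O` gives 6.6 uL/min in this assay, a value far enough from that of compound 1 to lie beyond the usual scatter. Compound 3 `COc1cc(=O)n(C)cc1-c1ccnc2[nH]c(C3CCN(CC(=O)N(C)C)CC3)cc12` has not yet been measured. It differs from compound 1 in one place: a group of 10 heavy atoms (7 carbon, 1 nitrogen, 2 oxygen; one six-membered aromatic ring with 1 hetero atom) in place of a group of 9 heavy atoms (7 carbon, 1 oxygen, 1 fluorine; one six-membered aromatic ring of carbon only), on an aromatic carbon, on an aromatic carbon of the core, opposite the ring nitrogen. Within the data shown here, with compound 2 as the only guide, a group of this kind on the core accompanies a lower number than compound 1 shows, so a downward step of moderate size is expected, a 3.8-fold lower number from compound 1 to compound 3 (0.58 log units; beyond the scatter). Compound 3 is accordingly expected to give about 10 uL/min in this assay, with a range from 4 uL/min to 25 uL/min.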

Compound 3, intrinsic clearance in a liver preparation (reported as CLH), per the amount of preparation that the assay uses: < 1 uL/min
Compound 3: only a limit was reported (the forecaster's own chance of this, stated with the estimate: 5%); middle value at least 10-fold (1.00 log units) from the limit.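

Within the data shown here, this gives the first one-place step between measured compounds on the shared core, and it is large: replacing the 4-fluoro-2-methoxyphenyl group on the aromatic carbon opposite the ring nitrogen gives an at least 38-fold lower number from compound 1 to compound 3 (1.57 log units; beyond the scatter) in this assay. The change at this position alone is therefore enough to move the number well beyond the scatter, without any change elsewhere on the core of compound 1. The reading for compound 3 is a limit and not a number, so the full size of the step stays unfixed: the limit of < 1 uL/min in this assay, at which 1 of the 3 values shown sits.

From the compounds shown here alone, whether the step belongs to the ring nitrogen, the ring carbonyl or the methyl on that nitrogen stays open; all of these enter together. Going by these compounds, how a plain pyridine ring or an unsubstituted phenyl ring would read at this position also remains unknown.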